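Methoxy in Place of Fluoro on the Outer Phenyl

A few compounds are considered here, and "the series" means these few. Any claim that something is new, unique, unknown or untested is made for them only; others in the source may bear on it.

Compound 1 `CCNC(=O)c1cc(Oc2ccc(NC(=O)c3cc4cccnc4n(-c4ccccc4)c3=O)cc2)ccn1`: 220 nM
Compound 2 `CCNC(=O)c1cc(Oc2ccc(NC(=O)c3cc4cccnc4n(-c4ccc(F)cc4)c3=O)cc2)ccn1`: 190 nM

Of the compounds shown here, two have been measured in a functional assay on HT-29 cells (Homo sapiens) for antiproliferative activity, read by MTT assay, with a stated time of 72 h; on this read-out lower numbers stand for stronger inhibition and higher numbers for weaker inhibition. Compound 2 gives the lowest of the two numbers, with 190 nM, but the step of a 1.2-fold lower number from compound 1 to compound 2 (0.06 log units; within the scatter) lies within the scatter, so compound 1 and compound 2 cannot be told apart on this read-out. Compound 3 `CCNC(=O)c1cc(Oc2ccc(NC(=O)c3cc4cccnc4n(-c4ccc(OC)cc4)c3=O)cc2)ccn1` is not yet measured; it differs from compound 2 by methoxy in place of fluoro on an aromatic carbon.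

Among the compounds with values here, only one measured step bears on this change: a 1.2-fold lower number from compound 1 to compound 2 (0.06 log units; within the scatter), which placed fluoro on the same aromatic carbon and moved the number by an amount within the scatter. A single small step on that carbon gives little ground to expect a large shift from methoxy either way. The expected step of a 1.2-fold higher number from compound 2 to compound 3 (0.06 log units; within the scatter) is therefore none beyond the scatter. Compound 3 is estimated at 220 nM in this assay, within a range of 90 nM to 550 nM.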

Compound 3, half-maximal inhibitory concentration: 3350 nM
Compound 3: the middle estimate sits 15-fold (1.18 log units) below what was measured; the whole stated range lies below it.
By their numbers in this assay, from the lowest: compounds 2 and 1 (each within the scatter of the next); then compound 3.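

The aromatic carbon on the outer phenyl turns out to respond strongly to what it carries: in this assay the change from 4-fluorophenyl to 4-methoxyphenyl gives an 18-fold higher number from compound 2 to compound 3 (1.25 log units; beyond the scatter) and methoxy in place of hydrogen gives a 15-fold higher number from compound 1 to compound 3 (1.18 log units; beyond the scatter) on the same carbon. Hydrogen and fluoro cannot be told apart here, so the small step seen earlier does not extend to every group placed on this carbon; methoxy, with its oxygen and its carbon, stands clearly apart from both. Nothing measured here explains this large change.

Whether the oxygen, the added carbon or the two together account for the change stays open, and a hydroxyl, a methyl or a chloro group on this carbon would help to separate them. Going by these compounds, whether methoxy would have a similar effect on another carbon of this ring also remains open.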